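The source may hold more compounds than are shown below. What is called first, only, known or untested is meant among the compounds shown, and "the series" means these compounds.

Measured compounds in a functional assay on HCT-116 cells (Homo sapiens) for inhibition, read by MTT assay, with a stated time of 72 h; a higher number here means a weaker inhibitor, a lower number a stronger inhibitor:
compound 1 `O=C1Nc2ccc(Cl)cc2/C1=N/NC(=S)N1CCN(c2ccc([N+](=O)[O-])cc2)CC1`, 12000 nM
compound 2 `O=C1Nc2ccccc2/C1=N/NC(=S)Nc1ccccc1`, a limit of the assay, > 100000 nM
compound 3 `O=C1Nc2ccc(Cl)cc2/C1=N/NC(=S)Nc1ccccc1`, 30800 nM

Of the two real numbers, compound 3 gives the higher one and is thus the weaker inhibitor of the pair, with compound 1 sitting lower. Compound 2 reaches only a limit of this assay, with no number behind it. Within the data shown here, the single step measured so far, an at least 3.2-fold lower number from compound 2 to compound 3 (0.51 log units; beyond the scatter), comes from chloro in place of hydrogen on an aromatic carbon, a chloro that compound 3 keeps. Compound 4 `Cc1ccc(NC(=S)N/N=C2\C(=O)Nc3ccc(Cl)cc32)c(C)c1` differs from compound 3 in 2,4-dimethylphenyl in place of phenyl on an amide-type nitrogen. Among the measured compounds shown here, no measured step touches that part of the molecule. The expected step is a 1.2-fold lower number from compound 3 to compound 4 (0.09 log units; within the scatter), nothing beyond the scatter. Compound 4 is therefore estimated at 25000 nM, between 8000 nM and 80000 nM.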

Compound 4, half-maximal inhibitory concentration: > 100000 nM
Compound 4: only a limit was reported (the forecaster's own chance of this, stated with the estimate: 20%); middle value at least 4.0-fold (0.60 log units) away from the limit.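

Putting 2,4-dimethylphenyl in place of phenyl on the amide-type nitrogen gives an at least 3.2-fold higher number from compound 3 to compound 4 (0.51 log units; beyond the scatter) in this assay, so this part of the molecule, untouched by the earlier step, does affect inhibition. The chloro kept by compound 4 does not preserve a measurable value once this group changes. The result for compound 4 is a limit, so the full size of the change cannot be read: the limit of > 100000 nM in this assay, at which 2 of the 4 values shown sit.

The compounds shown leave open which of the two methyl groups accounts for the change, and how a methoxy group or an amine on that phenyl would behave.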